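This account rests on a few compounds, and the source may have more. Where it says the series, first, only, none or still open, it means among the compounds named here.

In a functional assay on MAXF 401NL cells (Homo sapiens) for cytotoxicity, read by propidium iodide staining, with a stated time of 4 days (a lower number here means a stronger inhibitor, a higher number a weaker inhibitor), compound 1 `CNC1=CC(=O)c2c(cnc(C)c2C)C1=O` gives 47800 nM. Compound 2 `CNC1=CC(=O)c2cc(C)ncc2C1=O` gives 17300 nM in this assay, and the step of a 2.8-fold lower number from compound 1 to compound 2 (0.44 log units; beyond the scatter) is beyond the scatter. Going by the values given here, compound 2 therefore holds the lowest of the two numbers measured so far, with compound 1 the only other measured compound and standing higher by that step.

Compound 3 `Cc1cc2c(cn1)C(=O)C(NCl)=CC2=O` differs from compound 2 in one place: chloro in place of methyl on an amine nitrogen. Among the compounds with values here, the single measured step concerns a methyl on an aromatic carbon, not a group on the amine nitrogen, so it does not bear on this change, and no other step is available. Within the data shown here, with no measured step to give a direction, the step of a 1.0-fold lower number from compound 2 to compound 3 (0.01 log units; within the scatter) is expected to lie within the scatter, though with a wide range on either side. Compound 3 is accordingly estimated at 17000 nM in this assay, between 5000 nM and 60000 nM.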

Compound 3, half-maximal inhibitory concentration: 3550 nM
Estimate against measurement, compound 3: 4.8-fold (0.68 log units) above; measured number below the stated range.
By their numbers in this assay, from the lowest: compound 3; then compound 2; then compound 1.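

In this assay, going by these compounds alone, chloro in place of methyl on an amine nitrogen gives a 4.9-fold lower number from compound 2 to compound 3 (0.69 log units; beyond the scatter), the first reading at this position. The earlier step concerned a methyl on an aromatic carbon, so only now is it seen that the number also responds to the group on the amine nitrogen. An exchange of one heavy atom for another here is enough to move the number beyond the scatter. Nothing measured among these compounds accounts for this change.

Going by these compounds, with only methyl and chloro seen on the amine nitrogen, it stays open how a bromo, an ethyl or a plain hydrogen there would read in this assay. On these data alone, it is also open whether chloro would give a similar step on the core of compound 1, which carries the additional methyl.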